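Dimethylamino in place of methyl on a sulfone-bearing core

The compounds below may be only part of what the source reports. "The series", "measured", "known", "first", "only" and "open" are said of these compounds alone.

Of the compounds shown here, two have been measured in an assay on cells for inhibition of ileal sodium/bile acid cotransporter (Homo sapiens); a higher number here means a weaker inhibitor, a lower number a stronger inhibitor. Compound 1 `CCCCC1(CCCC)CS(=O)(=O)c2ccc([N+](C)(C)C)cc2[C@@H](c2ccccc2)[C@H]1O` gives 210 nM. Compound 2 `CCCCC1(CCCC)CS(=O)(=O)c2ccc(C)cc2[C@@H](c2ccc(F)cc2)[C@H]1O` gives 46 nM, the lower of the two numbers, and its gap to compound 1 lies beyond the scatter of the method. Compound 3 `CCCCC1(CCCC)CS(=O)(=O)c2ccc(N(C)C)cc2[C@@H](c2ccc(F)cc2)[C@H]1O` has not yet been measured in this assay. It differs from compound 2 in one place: dimethylamino in place of methyl on an aromatic carbon. Among the measured compounds shown here, no measured pair shows this change on its own, so the direction of the step can only be estimated. The two measured compounds differ in two places at once and give no guide to a change on this one aromatic carbon alone. Compound 3 is expected to stay close to compound 2, with a step of a 1.2-fold lower number from compound 2 to compound 3 (0.06 log units; within the scatter) that does not go beyond the scatter. The estimated value for compound 3 is 40 nM, between 12 nM and 130 nM.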

Compound 3, half-maximal inhibitory concentration: 10 nM
Estimate against measurement, compound 3: 4.0-fold (0.60 log units) above; measured number below the stated range.
By their numbers in this assay, from the lowest: compound 3; then compound 2; then compound 1.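

In this assay, the aromatic carbon that carries methyl in compound 2 proves responsive to the group placed on it: dimethylamino there gives a 4.6-fold lower number from compound 2 to compound 3 (0.66 log units; beyond the scatter). Among the compounds shown here, this is the only step that changes one place alone, and it shows that a group containing nitrogen can stand on this carbon with a lower number, not a higher one. No measurement shown here accounts for the step.

The compounds shown leave open whether the nitrogen or the bulk of the group matters more, as neither the smaller amine methylamino nor the all-carbon isopropyl appears among them. From the compounds shown here alone, how the trimethylammonium group of compound 1 compares on this carbon also stays open, as compound 1 differs from compound 2 and compound 3 in a second place too.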